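Cytotoxicity notes on the ring-nitrogen substituent series

The compounds below may be only part of what the source reports. "The series", "measured", "known", "first", "only" and "open" are said of these compounds alone.

Measured compounds:
compound 1 `CS(=O)(=O)CCCn1c(Cn2c(=O)n(C3COC3)c3ccncc32)cc2cc(Cl)ccc21`: > 50000 nM, a limit rather than a number
compound 2 `CC1(n2c(=O)n(Cc3cc4cc(Cl)ccc4n3CCCS(C)(=O)=O)c3cnccc32)CC1`: > 50000 nM, a limit rather than a number
compound 3 `CC(C)n1c(=O)n(Cc2cc3cc(Cl)ccc3n2CCCS(C)(=O)=O)c2cnccc21`: > 50000 nM, a limit rather than a number

All three values come from an ADME assay on HeLa cells (Homo sapiens) for cytotoxicity, read by ATP content, with a stated time of 3 days; on this read-out higher numbers stand for lower toxicity in this test and lower numbers for higher toxicity in this test. Compound 3 stands only at a limit in this assay, with no number behind it. The same holds for its two neighbours, so the step that the two limits leave unreadable from compound 1 to compound 2, the step that the two limits leave unreadable from compound 1 to compound 3 and the step that the two limits leave unreadable from compound 2 to compound 3 are all unreadable; the whole set rests on (the limit of > 50000 nM in this assay, at which 3 of the 3 values shown sit).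

Compound 4 `CS(=O)(=O)CCCn1c(Cn2c(=O)[nH]c3ccncc32)cc2cc(Cl)ccc21` is not yet measured. The change is hydrogen in place of isopropyl on an aromatic nitrogen. Among the measured compounds shown here, none of the measured steps can be read, so no size or direction beyond the scatter is expected for compound 4; the expectation is that the step that the limit leaves unreadable from compound 3 to compound 4 again ends at the limit. Compound 4 is therefore estimated at 80000 nM, with a range from 30000 nM to 250000 nM, most likely reported as a limit only.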

Compound 4, half-maximal cytotoxic concentration: > 50000 nM
Compound 4: only a limit was reported; the forecaster's own chance of this, stated with the estimate: 85%; the middle value does not contradict the limit.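

Compound 4 gives > 50000 nM in this assay, a limit rather than a number. Among the compounds shown here, no step from compound 1, compound 2 or compound 3 to compound 4 can be read: the limit of > 50000 nM in this assay, at which 4 of the 4 values shown sit.

The compounds shown leave open whether the hydrogen, isopropyl, 1-methylcyclopropyl and oxetan-3-yl compounds differ at all in cytotoxicity.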